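Allyl for Butyl Carbamate on a Selenocyanate Aryl Core

The source may report more compounds than this note shows. Statements on the series, on what has been measured and on what is new or still open speak of the compounds shown alone.

Measured compounds:
compound 1 `CCCCOC(=O)Nc1ccc([Se]C#N)cc1` gives 59700 nM
compound 2 `CCOC(=O)Nc1ccc([Se][Se]c2ccc(NC(=O)OCC)cc2)cc1` gives 68300 nM
compound 3 `Cc1ccc(OC(=O)Nc2ccc([Se][Se]c3ccc(NC(=O)Oc4ccc(C)cc4)cc3)cc2)cc1` gives 74000 nM

In a functional assay on MCF7 cells (Homo sapiens) for cytotoxicity, read by MTT assay, with a stated time of 72 h (a lower number here means that less compound is tolerated, a higher number that more compound is tolerated), compound 1 stands alongside compound 2 and compound 3, all three numbers lying within the scatter of one another, so none can be set apart from the others. The unmeasured compound 4 `C=CCOC(=O)Nc1ccc([Se]C#N)cc1` differs from compound 1 by vinyl in place of propyl on a saturated chain carbon bound to an oxygen next to a carbonyl group. Within the data shown here, no step between measured compounds is available to calibrate this change. A shift of this small size, exchanging one short chain for another with the same count of donors and acceptors, is expected to give no step beyond the scatter: the step from compound 1 to compound 4 is estimated as a 1.0-fold higher number from compound 1 to compound 4 (0.00 log units; within the scatter). For compound 4 the expected value in this assay is 60000 nM, with a range from 30000 nM to 120000 nM.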

Compound 4, concentration lethal to 50% of the cells: 71200 nM
For compound 4 the middle estimate is 1.2-fold (0.07 log units) below the measured one; measured number inside the range.
By their numbers in this assay, from the lowest: compounds 1, 2, 4 and 3 (each within the scatter of the next).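

In this assay, among these compounds, the exchange of butyl for allyl, read as vinyl in place of propyl on a saturated chain carbon bound to an oxygen next to a carbonyl group, gives a 1.2-fold higher number from compound 1 to compound 4 (0.08 log units; within the scatter) and so adds the only step between compounds differing in one place. At this position, a double bond outside aromatic rings therefore leaves the number indistinguishable from that of the saturated chain. Nothing available accounts for this result. On these data alone, whether a longer chain, a benzyl group or an amine at this place would give a step beyond the scatter remains open.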